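A few compounds are considered here, and "the series" means these few. Any claim that something is new, unique, unknown or untested is made for them only; others in the source may bear on it.

Measured compounds:
- compound 1, `COc1cccc(-c2nc3c(-c4ccc(C5CCNCC5)cc4)n[nH]c3c(=O)n2NC(=O)c2ccncc2)c1`: 37%
- compound 2, `CCCCCc1nc2c(-c3ccc(Cl)cc3)n[nH]c2c(=O)n1NC(=O)c1ccccc1`: 88.7%
- compound 3, `CCCCCc1nc2c(-c3ccc(Cl)cc3)n[nH]c2c(=O)n1NC(=O)c1cccc(C)c1`: 88.8%

In a functional assay on DU-145 cells (Homo sapiens) for cytotoxicity, read by sulforhodamine B assay, with a stated time of 2 days, tested at 100 uM (on this read-out lower numbers stand for less inhibition and higher numbers for more inhibition at the one concentration tested (going by the name of the read-out)), compound 3 gives the highest of the three numbers, yet compound 2 sits within the scatter of it, so the two cannot be told apart; compound 1 lies well below both. Going by the values given here, the one step that exists between these compounds, a number 0.1 percentage points higher from compound 2 to compound 3 (within the scatter), comes from a methyl in place of hydrogen on an aromatic carbon and did not move the read-out beyond the scatter. Compound 1 differs from compounds 2 and 3 in several places at once, so its value speaks only for itself.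

Compound 4, `Cc1cccc(C(=O)Nn2c(CC3CCCCC3)nc3c(-c4ccc(Cl)cc4)n[nH]c3c2=O)c1`, is reached from compound 3 by cyclohexyl in place of butyl on a saturated chain carbon bound to an aromatic carbon. Among the compounds with values here, no measured step touches this part of the structure: the only step known concerns the aromatic substituent, not the saturated chain. Within the data shown here, there is therefore no direct precedent for the size or direction of the change in this assay.

Given that compounds 2 and 3 both sit high in this assay and that the change keeps all other parts of compound 3 intact, compound 4 is expected to remain in the high range, with the step of a number 6.8 percentage points lower from compound 3 to compound 4 (within the scatter) estimated as small, most likely within the scatter but allowed to lean slightly downward. Compound 4 is estimated at 82%, with a range from 58% to 96%.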

Compound 4, a percentage reported as inhibition, at one concentration (the size of the read-out at that concentration, not a potency): 85.9%
Beside the measured number, compound 4's estimate is 3.9 percentage points below it; low and high end bracket the measured number.
By their numbers in this assay, from the lowest: compound 1; then compounds 4, 2 and 3 (each within the scatter of the next).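

In this assay, going by these compounds alone, the step of a number 2.9 percentage points lower from compound 3 to compound 4 (within the scatter) gives the first measured view of this position, where the earlier compounds offered only a change on an aromatic carbon. Here, on a saturated chain carbon bound to an aromatic carbon, the assay does not distinguish butyl from cyclohexyl; read one bond further out, it does not distinguish pentyl from cyclohexylmethyl, so replacing the open chain with a six-membered non-aromatic ring of carbon only produces no change beyond the scatter in this pair. Nothing available offers a reason for this result.

This single pair leaves open whether the number would stay level with groups of another kind at this position, such as an amine or a carboxylic acid at the end of the chain, a phenyl ring or a much longer chain. As far as these compounds go, since the read-out comes from one concentration and gives no potency, it also remains open whether compound 3 and compound 4 would separate at lower concentrations.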